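The compounds below may be only part of what the source reports. "The series", "measured", "known", "first", "only" and "open" are said of these compounds alone.

The series shares one fused core, seen in compound 1 `COc1ccc2nc(-c3ccccc3)cc(-c3ccccc3)c2c1`; in a functional assay on Hep2C cells (Homo sapiens) for antiproliferative activity, read by MTT assay, with a stated time of 24 h (a lower number here means a stronger inhibitor, a higher number a weaker inhibitor), compound 1 gives 496000 nM. Compound 2 `COc1cc(-c2cc(-c3ccccc3)c3cc(Br)ccc3n2)cc(OC)c1OC` carries no result in this assay, recorded as "not determined" (no result reported). Compound 3 `Brc1ccc2nc(C3CCCCC3)cc(-c3ccccc3)c2c1` likewise carries no result in this assay, recorded as "not determined" (no result reported), so it stands without a number of its own, and the only figure in the set is the weak one from compound 1.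

The step to compound 4 `N#Cc1ccc(-c2cc(-c3ccccc3)c3cc(Br)ccc3n2)cc1` is the change (4-cyanophenyl in place of cyclohexyl on an aromatic carbon), that is, 4-cyanophenyl in place of cyclohexyl on an aromatic carbon, next to the ring nitrogen of the fused system. Among the compounds with values here, no measured pair in the set shows what this exchange does, so the expected size of the step in this assay cannot be read from a comparison; the single reference from compound 1 points to weak activity across the core, and compound 4 is expected to fall in that weak region too, with a wide uncertainty. For compound 4 the estimated value in this assay is 200000 nM, within a range from 40000 nM to 1000000 nM.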

Compound 4, half-maximal inhibitory concentration: 98800 nM
The estimate for compound 4 lay 2.0-fold (0.31 log units) above the measured number; the range from low to high includes it.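

No new step can be read from compound 3 to compound 4: only compound 4 has a number here. Nothing measured in the set bears on this result. The compounds shown leave open what, in this assay and on the shared core, the change from cyclohexyl to 4-cyanophenyl does.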